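This account rests on a few compounds, and the source may have more. Where it says the series, first, only, none or still open, it means among the compounds named here.

Measured so far:
compound 1 `C[S+]([O-])/C=C/c1cc(=O)c2ccccc2o1`: 1900 nM
compound 2 `CC(C)Oc1ccc2oc(/C=C/[S+](C)[O-])cc(=O)c2c1`: 1500 nM

Both numbers come from a functional assay on A549 cells (Homo sapiens) for cytotoxicity, with a stated time of 48 h; on this read-out lower numbers stand for stronger inhibition and higher numbers for weaker inhibition. Compound 2 gives the smaller of the two, separated from compound 1 by a 1.3-fold lower number from compound 1 to compound 2 (0.10 log units; within the scatter), which is within the scatter, so the two are not distinguished on this read-out.

Compound 3 `CC(C)CC(=O)Oc1ccc2oc(/C=C/[S+](C)[O-])cc(=O)c2c1` differs from compound 2 by isobutylcarbonyl in place of isopropyl on an oxygen on an aromatic ring. Among the measured compounds shown here, the only measured step touches the same oxygen on the aromatic ring and was within the scatter; no measured step covers an isobutylcarbonyl or an ester at this place. The expected step is therefore no change at the digits printed from compound 2 to compound 3 (within the scatter), nothing beyond the scatter. Compound 3 is estimated at 1500 nM (range 500 nM to 4500 nM).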

Compound 3, half-maximal inhibitory concentration: 2300 nM
The estimate for compound 3 lay 1.5-fold (0.19 log units) below the measured number; measured number inside the range.
By their numbers in this assay, from the lowest: compounds 2, 1 and 3 (each within the scatter of the next).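

With isobutylcarbonyl in place of isopropyl on the oxygen on the aromatic ring, this assay shows a 1.5-fold higher number from compound 2 to compound 3 (0.19 log units; within the scatter). Set against hydrogen on the aromatic carbon, (isobutylcarbonyl)oxy gives a 1.2-fold higher number from compound 1 to compound 3 (0.08 log units; within the scatter). Hydrogen, isopropoxy and (isobutylcarbonyl)oxy are therefore not distinguished on this read-out, so the larger group with its added hydrogen-bond acceptor separates nothing here, and no supporting evidence bears on this result. As far as these compounds go, whether an amine, a carboxylic acid or a longer alkyl chain at this place would shift the number beyond the scatter remains open.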